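Trifluoromethyl in place of trifluoromethoxy on compound 1

This account rests on a few compounds, and the source may have more. Where it says the series, first, only, none or still open, it means among the compounds named here.

The compounds were tested in a functional assay on HeLa cells (Homo sapiens) for cytotoxicity, read by MTT assay, with a stated time of 2 days; a higher number here means a weaker inhibitor, a lower number a stronger inhibitor. Compound 1 `Cc1ccc2c(=O)[nH]c(-c3cccc(OC(F)(F)F)c3)nc2c1` gives > 50000 nM in this assay, and that is a limit of the assay rather than a number. Compound 1 therefore sits at the limit of > 50000 nM in this assay, at which 1 of the 3 values shown sits, so its standing can be given only as that limit. Two further compounds give numbers in this assay: compound 2 `CCN(CC)c1ccc2nc(-c3ccccc3N(C)C)[nH]c(=O)c2c1` gives 70 nM, and compound 3 `Cc1ccc2nc(-c3ccccc3C)[nH]c(=O)c2c1` gives 4580 nM. For the measured compounds named here, none of these three compounds differs from another in one place alone, so no single step between measured compounds can be read from them.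

Compound 4 `Cc1ccc2c(=O)[nH]c(-c3cccc(C(F)(F)F)c3)nc2c1` is the compound not yet measured. It differs from compound 1 by trifluoromethyl in place of trifluoromethoxy on an aromatic carbon, a trifluoromethyl on an aromatic carbon where compound 1 carries a trifluoromethoxy. Going by the values given here, since compound 1 offers only a limit, no step in this assay can be inferred beyond the scatter for such a change, and no shift in either direction is expected. Compound 4 is expected to give about 50000 nM in this assay, in a range from 15000 nM to 150000 nM. The step expected from this estimate is a number no higher from compound 1 to compound 4 (the limit leaves the size open), and a further limit rather than a number is considered likely.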

Compound 4, half-maximal inhibitory concentration: > 50000 nM
Compound 4: no number, only a limit (the forecaster's own chance of this, stated with the estimate: 70%); the middle value sits exactly at the limit.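

Compound 1 and compound 4 both stand at a limit rather than a number in this assay, so no step between them can be read: the limit of > 50000 nM in this assay, at which 2 of the 4 values shown sit.

The compounds shown leave open whether trifluoromethyl in place of trifluoromethoxy changes the value at all.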